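A few compounds are considered here, and "the series" means these few. Any claim that something is new, unique, unknown or untested is made for them only; others in the source may bear on it.

Working notes on the series

Compound 1 `CN(C)CCCNc1nc(-c2ccc(NC(=O)Nc3ccccc3F)cc2)nc2ccsc12` and compound 2 `CN(C)CCCNc1nc(-c2ccc(NC(=O)Nc3ccccc3Cl)cc2)nc2ccsc12` share one core and differ only in the halogen on the terminal phenyl ring of the urea. In a functional assay on HT-29 cells (Homo sapiens) for cytotoxicity, read by MTT assay, with a stated time of 72 h (on this read-out lower numbers stand for stronger inhibition and higher numbers for weaker inhibition), compound 1 gives 470 nM, and compound 2 gives 390 nM. The change is chloro in place of fluoro on an aromatic carbon, and the step it made is a 1.2-fold lower number from compound 1 to compound 2 (0.08 log units; within the scatter); the two values are not distinguished by this assay.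

Compound 3 `CCN(CC)CCNc1nc(-c2ccc(NC(=O)Nc3ccc(F)cc3)cc2)nc2c(Cl)c(Cl)sc12` belongs to a second core; the difference between the two cores is not broken down here. In this assay compound 3 gives 650 nM, which stands within the scatter of both compound 1 and compound 2, so no order among the three can be read from these numbers.

Compound 4 `CCN(CC)CCNc1nc(-c2ccc(NC(=O)Nc3ccc(Cl)cc3)cc2)nc2c(Cl)c(Cl)sc12` is the still unmeasured partner of compound 3. The change is chloro in place of fluoro on an aromatic carbon. Among the compounds with values here, it is the same kind of change as the one from compound 1 to compound 2, but not the same: there the chloro sits ortho to a large group, here it sits para to a large group, and the core is different.

Because the earlier instance of this kind of change gave a 1.2-fold lower number from compound 1 to compound 2 (0.08 log units; within the scatter), the step from compound 3 to compound 4 is expected to be small as well, estimated as a 1.2-fold lower number from compound 3 to compound 4 (0.07 log units; within the scatter). Compound 4 is accordingly expected to give about 550 nM in this assay, with a likely range from 250 nM to 1200 nM.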

Compound 4, half-maximal inhibitory concentration: 430 nM
For compound 4 the middle estimate is 1.3-fold (0.11 log units) above the measured one, within the range that was stated.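

Chloro in place of fluoro on an aromatic carbon gives, on the core of compound 3, a step of a 1.5-fold lower number from compound 3 to compound 4 (0.18 log units; within the scatter) in this assay, so this assay does not distinguish the two compounds. Set beside the earlier step, the change reads as small on both cores, and the gap between the two steps cannot be told from the scatter: the same change on two cores in this assay, a 1.2-fold lower number (0.08 log units; within the scatter) from compound 1 to compound 2 and a 1.5-fold lower number (0.18 log units; within the scatter) from compound 3 to compound 4, 1.3-fold (0.10 log units) apart, within the scatter of two such steps. Within the data shown here, this shows that in these two pairs the exchange of fluoro for chloro leaves the read-out within its resolution on either core, but it does not show that the step has a fixed size or direction across the series, as both steps lie within the scatter, there are only two pairs, and the halogen does not stand in the same place on the terminal ring in both.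

The compounds shown leave open whether a methoxy, trifluoromethyl or nitrile group at the place of the halogen on the terminal phenyl ring would give a step that this assay can resolve. They also leave open whether the two cores would still read alike with a morpholine at the end of the side chain, or with the same halogen in the same place on both cores.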